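Working notes: from compound 1 to compound 4

A few compounds are considered here, and "the series" means these few. Any claim that something is new, unique, unknown or untested is made for them only; others in the source may bear on it.

Measured compounds:
Compound 1 `CC(C)(C)c1ccc(CNCCNS(=O)(=O)c2cc(C(F)(F)F)cc(C(F)(F)F)c2)cc1` in a functional assay on MCF7 cells (Homo sapiens) for inhibition, read by MTT assay, with a stated time of 72 h (on this read-out higher numbers stand for weaker inhibition of growth and lower numbers for stronger inhibition of growth), gives 13000 nM.
Compound 2 `O=S(=O)(NCCCCNCc1ccc(Br)cc1)c1cc(C(F)(F)F)cc(C(F)(F)F)c1` in this assay gives 1500 nM.
Compound 3 `O=S(=O)(NCCCNCc1ccc(Cl)cc1)c1cc(C(F)(F)F)cc(C(F)(F)F)c1` in this assay gives 2400 nM.

Compound 1 has the highest number of the three in this assay; the gaps to compound 3 and to compound 2 are both beyond the scatter. Compound 4 `O=S(=O)(NCCNCc1ccc(-c2ccccc2)cc1)c1cc(C(F)(F)F)cc(C(F)(F)F)c1` is not yet measured. It differs from compound 1 in one place: phenyl in place of tert-butyl on an aromatic carbon.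

Within the data shown here, the only measured step in the set is a 1.6-fold higher number from compound 2 to compound 3 (0.20 log units; within the scatter). Among the measured compounds shown here, that step changes a halogen and the chain length at once and says nothing about the group at the place where compound 1 carries tert-butyl, so no measured step bears directly on the change to compound 4. The whole set shows that the chain and the benzyl substituent together shift the number beyond the scatter between compound 1 and compounds 2 and 3, so a shift of comparable size is plausible here, but its direction is not anchored by any shown pair. The expectation is therefore centred near compound 1, leaning slightly toward a lower number, with a wide range.

Compound 4 is estimated at 8000 nM, from 2500 nM to 25000 nM, which means an expected step of a 1.6-fold lower number from compound 1 to compound 4 (0.21 log units; within the scatter).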

Compound 4, concentration for 50% growth inhibition: 1400 nM
Compound 4: middle estimate off by 5.7-fold (0.76 log units), on the high side; measured number outside the range, below it.
By their numbers in this assay, from the lowest: compounds 4, 2 and 3 (each within the scatter of the next); then compound 1.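

In this assay, phenyl in place of tert-butyl on an aromatic carbon, para to a large group, gives a 9.3-fold lower number from compound 1 to compound 4 (0.97 log units; beyond the scatter), with the rest of the structure unchanged. The earlier compounds shown here offered no step at this position, and this pair shows that the position is not indifferent: swapping a group with no ring for one six-membered aromatic ring of carbon only moves the number beyond the scatter, and towards stronger inhibition of growth. Nothing available here explains why this change moves the number.

Among these compounds, the single pair cannot separate the presence of an aromatic ring from the larger group as such, and a cyclohexyl group, a pyridine ring or a phenyl carrying a carboxylic acid at this place would bear on that question. As far as these compounds go, whether the step holds on a longer chain, such as the butyl-length chain of compound 2, also stays open, as the pair speaks only for the chain shared by compound 1 and compound 4.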